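The source may report more compounds than this note shows. Statements on the series, on what has been measured and on what is new or still open speak of the compounds shown alone.

Compounds measured so far:
compound 1 `NS(=O)(=O)c1ccc2nc(-c3ccc(-c4ccccc4F)cc3)[nH]c2c1` gives 343 nM in an assay on isolated protein for inhibition of acyl-CoA desaturase 1 (Rattus norvegicus); on this read-out lower numbers stand for stronger inhibition and higher numbers for weaker inhibition;
compound 2 `CCS(=O)(=O)c1ccc2nc(-c3ccc(-c4ccccc4F)cc3)[nH]c2c1` gives 1250 nM in this assay;
compound 3 `CS(=O)(=O)c1ccc2nc(-c3ccc(-c4ccc(Cl)cc4)cc3)[nH]c2c1` is reported in this assay only as a limit, > 20000 nM.

Compound 3 therefore stands at the weak end of the numbers shown, where its value is a limit of the assay rather than a number (the limit of > 20000 nM in this assay, at which 1 of the 3 values shown sits). Compound 4 `CS(=O)(=O)c1ccc2nc(-c3ccc(-c4cccc(F)c4)cc3)[nH]c2c1` differs from it in one place: 3-fluorophenyl in place of 4-chlorophenyl on an aromatic carbon. For the measured compounds named here, none of the measured steps touches this part of the structure; the only step recorded, a 3.6-fold higher number from compound 1 to compound 2 (0.56 log units; beyond the scatter), concerns the group on the sulfonyl sulfur, which compound 3 and compound 4 share. Compound 1 and compound 2 both carry a fluorine on the outer ring and both give numbers, which is the closest point of comparison for compound 4. Going by the values given here, with no direct precedent, the size and direction of the step are uncertain, and compound 4 is estimated to come out stronger than the limit of compound 3, as an at least 4.0-fold lower number from compound 3 to compound 4 (0.60 log units; beyond the scatter). Compound 4 is expected to give about 5000 nM in this assay, within a range from 800 nM to 25000 nM.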

Compound 4, half-maximal inhibitory concentration: 21 nM
Compound 4: middle estimate off by 240-fold (2.38 log units), on the high side; the measured number lies below the stated range.
By their numbers in this assay, from the lowest: compound 4; then compound 1; then compound 2. At a limit, above all of these: compound 3.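

In this assay, putting 3-fluorophenyl in place of 4-chlorophenyl, on an aromatic carbon para to a large group, gives an at least 950-fold lower number from compound 3 to compound 4 (2.97 log units; beyond the scatter), while the group on the sulfonyl sulfur stays the same. For the compounds shown here, the only earlier step, a 3.6-fold higher number from compound 1 to compound 2 (0.56 log units; beyond the scatter), concerned that sulfur group and was modest, whereas this one is large and shows that the outer aromatic ring can decide whether a compound gives a measurable number at all. Compound 3 is reported only as a limit, so this step is itself a bound: the limit of > 20000 nM in this assay, at which 1 of the 4 values shown sits.

On these data alone, the change swaps the halogen and its place together, so it remains open which of the two carries the step; 3-chlorophenyl or 4-fluorophenyl would separate them. As far as these compounds go, how a methoxy group, a nitrile or an amine on this ring would read also remains open.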